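Extending the Bromoalkoxy Chain of Compound 3

A few compounds are considered here, and "the series" means these few. Any claim that something is new, unique, unknown or untested is made for them only; others in the source may bear on it.

In a functional assay on HepG2 cells (Homo sapiens) for antiproliferative activity, read by MTT assay, with a stated time of 48 h (a higher number here means a weaker inhibitor, a lower number a stronger inhibitor), compound 3 `COc1ccc(N(C)c2ccnc(Cl)n2)cc1OCCCBr` gives 1240 nM, the lowest of the three numbers, against compound 1 `COc1ccc(N(C)c2ccnc(Cl)n2)cc1Cl` at 2630 nM and compound 2 `COc1ccc(N(C)c2ccnc(Cl)n2)cc1[N+](=O)[O-]` at 6120 nM. Compound 4 `COc1ccc(N(C)c2ccnc(Cl)n2)cc1OCCCCCBr` changes only the chain: 2-bromoethyl in place of bromo on a saturated chain carbon, three bonds along the chain from an oxygen on an aromatic ring, so that 3-bromopropyl becomes 5-bromopentyl. The nearest evidence is a 2.1-fold lower number from compound 1 to compound 3 (0.33 log units; beyond the scatter) and a 4.9-fold lower number from compound 2 to compound 3 (0.69 log units; beyond the scatter). For the measured compounds named here, both steps are modest, but each replaces a group on an aromatic carbon, and no measured step alters chain length. Only a small shift toward a lower number, within the scatter, is therefore expected, namely a 1.2-fold lower number from compound 3 to compound 4 (0.09 log units; within the scatter). For compound 4, the estimated value is 1000 nM, with an expected range of 430 nM to 2400 nM.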

Compound 4, half-maximal inhibitory concentration: > 10000 nM
Compound 4: no number, only a limit; the forecaster's own chance of this, stated with the estimate: 3%; at least 10-fold (1.00 log units) between middle value and limit.
By their numbers in this assay, from the lowest: compound 3; then compound 1; then compound 2. At a limit, above all of these: compound 4.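

Lengthening 3-bromopropyl to 5-bromopentyl gives an at least 8.0-fold higher number from compound 3 to compound 4 (0.90 log units; beyond the scatter), so this chain position responds strongly to a change that no earlier step had touched. The longer chain also compares poorly with the groups on the aromatic carbon, with an at least 3.8-fold higher number from compound 1 to compound 4 (0.58 log units; beyond the scatter) and an at least 1.6-fold higher number from compound 2 to compound 4 (0.21 log units; that floor lies within the scatter). Compound 4 gives only a limit, not a number: the limit of > 10000 nM in this assay, at which 1 of the 4 values shown sits.

The compounds shown leave open whether 4-bromobutyl would keep or lose the value of compound 3. They also leave open whether the bromo group matters, which an amine in its place would test.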